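Working notes: bromo to methyl on compound 3

The source may report more compounds than this note shows. Statements on the series, on what has been measured and on what is new or still open speak of the compounds shown alone.

Compound 3 `CC(C)(C)NCc1c(C(=O)O)nn(-c2ccccc2)c1-c1ccc(Br)cc1` gives only a limit in a functional assay on NCI-H460 cells (Homo sapiens) for inhibition, read by sulforhodamine B assay, with a stated time of 48 h (on this read-out higher numbers stand for weaker inhibition of growth and lower numbers for stronger inhibition of growth), > 585000 nM, and no number. Compound 2 `CC(C)(C)NCc1c(C(=O)O)nn(-c2ccccc2)c1-c1ccc(F)cc1` likewise gives only a limit, > 680000 nM. Compound 1 `CCOC(=O)c1nn(-c2ccccc2)c(-c2ccc(Br)cc2)c1CNC(C)(C)C` has two entries, 118000 nM; > 509000 nM (2 entries). On these figures, compound 3 therefore cannot be ranked against either of the other two compounds.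

Compound 4 `Cc1ccc(-c2c(CNC(C)(C)C)c(C(=O)O)nn2-c2ccccc2)cc1` differs from compound 3 by methyl in place of bromo on an aromatic carbon, para to a large group. For the measured compounds named here, the one measured step that bears on this change is a step that the two limits leave unreadable from compound 2 to compound 3, with bromo in place of fluoro on an aromatic carbon. Going by the values given here, it gives no size to carry over, and the series offers no measured step for methyl.

No step beyond the scatter is therefore expected in this assay, and no direction can be assigned. The estimated change is a step that the limit leaves unreadable from compound 3 to compound 4. This expectation rests on compound 3, whose limit is > 585000 nM. Compound 4 is expected near 650000 nM, with an estimated range from 250000 nM to 1000000 nM. A limit rather than a number is the likeliest report.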

Compound 4, concentration for 50% growth inhibition: > 688000 nM
Compound 4: a limit, no number (the forecaster's own chance of this, stated with the estimate: 85%); middle value at least 1.0-fold (0.02 log units) away from the limit.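

In this assay compound 4 gives > 688000 nM, which is a limit. Compound 2 and compound 3 also give only limits, so neither step to compound 4 can be read. Still open, going by these compounds, is whether compound 2, compound 3 and compound 4, carrying fluoro, bromo and methyl, differ at all in this assay.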